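Moving a fluorine on a Fluorophenyl Enone Pair

The source may report more compounds than this note shows. Statements on the series, on what has been measured and on what is new or still open speak of the compounds shown alone.

Of the compounds shown here, three have been measured so far. Compound 1 `CC(=O)OC/C(=C\c1ccc(F)cc1)C(=O)c1ccccc1` and compound 2 `CC(=O)OC/C(=C\c1ccccc1F)C(=O)c1ccccc1` share one core; compound 3 `C=C(C/C(=C\c1ccc(F)cc1)C(=O)c1ccccc1)C(=O)c1ccccc1` is built on a different core, and the difference between the two cores is not broken down here. In a functional assay on HBL-100 cells (Homo sapiens) for inhibition, read by sulforhodamine B assay, with a stated time of 48 h (on this read-out higher numbers stand for weaker inhibition of growth and lower numbers for stronger inhibition of growth), compound 1 gives 17000 nM, and compound 2 gives 17000 nM. For the measured compounds named here, the only change between them is 2-fluorophenyl in place of 4-fluorophenyl on a double-bonded chain carbon bound to a double-bonded chain carbon, and the step of no change at the digits printed from compound 1 to compound 2 (within the scatter). In this assay compound 3 gives 14000 nM, which lies close to the numbers of compound 1 and compound 2, within the scatter of either.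

Compound 4 `C=C(C/C(=C\c1ccccc1F)C(=O)c1ccccc1)C(=O)c1ccccc1` is not yet measured. It differs from compound 3 by 2-fluorophenyl in place of 4-fluorophenyl on a double-bonded chain carbon bound to a double-bonded chain carbon, the same change that turns compound 1 into compound 2. Because the step of no change at the digits printed from compound 1 to compound 2 (within the scatter) was within the scatter, the corresponding step from compound 3 to compound 4 is expected to be small as well, estimated as no change at the digits printed from compound 3 to compound 4 (within the scatter). On that basis compound 4 is expected to give about 14000 nM in this assay, with a likely range from 7000 nM to 28000 nM.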

Compound 4, concentration for 50% growth inhibition: 15000 nM
Compound 4: middle estimate off by 1.1-fold (0.03 log units), on the low side, within the range that was stated.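

In this assay, putting 2-fluorophenyl in place of 4-fluorophenyl on the second core gives a 1.1-fold higher number from compound 3 to compound 4 (0.03 log units; within the scatter), so the swap leaves the number essentially where it was. Set side by side, the two cores respond to this change in the same way: the same change on two cores in this assay, no change at the digits printed (within the scatter) from compound 1 to compound 2 and a 1.1-fold higher number (0.03 log units; within the scatter) from compound 3 to compound 4, 1.1-fold (0.03 log units) apart, within the scatter of two such steps

This shows that the swap carries over between these two cores only in the sense that it makes no real difference on either one; it does not show that a change with a large effect would carry over equally well, and two cores are too few to make a rule for the whole series.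

The compounds shown leave open what happens when the fluorine gives way to a different group, such as an amine or a carboxylic acid on the phenyl ring, where a step large enough to compare between cores might appear. They also leave open whether the same picture holds on any third core or outside this assay.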